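The source may hold more compounds than are shown below. What is called first, only, known or untested is meant among the compounds shown, and "the series" means these compounds.

In a functional assay on MCF7 cells (Homo sapiens) for cytotoxicity, read by MTT assay, with a stated time of 72 h (on this read-out lower numbers stand for stronger inhibition and higher numbers for weaker inhibition), compound 1 (`O=C(NCCCNc1c(C(=O)NCc2ccc(F)cc2)nc(Br)c2cccnc12)c1ccccc1`) gives 2000 nM. Compound 2 (`CNCCCNc1c(C(=O)NCc2ccc(F)cc2)nc(Br)c2cccnc12`) gives > 10000 nM, which is a limit. Compound 3 (`COC(=O)CNc1c(C(=O)NCc2ccc(F)cc2)nc(Br)c2cccnc12`) gives > 10000 nM, also a limit and not a number, so compound 3 stands at the limit of > 10000 nM in this assay, at which 2 of the 3 values shown sit. The change to compound 4 (`NCCCCCCNc1c(C(=O)NCc2ccc(F)cc2)nc(Br)c2cccnc12`) is 5-aminopentyl in place of methoxycarbonyl on a saturated chain carbon bound to a nitrogen on an aromatic ring. Within the data shown here, two measured steps bear on it: an at least 5.0-fold higher number from compound 1 to compound 3 (0.69 log units; beyond the scatter), and an at least 5.0-fold higher number from compound 1 to compound 2 (0.69 log units; beyond the scatter). Compound 2 carries a 2-(methylamino)ethyl group on the same chain carbon and gives no readable number in a step that the two limits leave unreadable from compound 2 to compound 3, so 5-aminopentyl is expected to bring only a modest move towards lower numbers, and possibly none that can be read. The expected step is an at least 1.4-fold lower number from compound 3 to compound 4 (0.15 log units; that floor lies within the scatter). For compound 4 the estimated value is 7000 nM, with an expected range of 2000 nM to 20000 nM.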

Compound 4, half-maximal inhibitory concentration: 2000 nM
Compound 4: the middle estimate sits 3.5-fold (0.54 log units) above what was measured; low and high end bracket the measured number.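

On this position, the 6-aminohexyl chain gives a readable number where the (methoxycarbonyl)methyl group does not: an at least 5.0-fold lower number from compound 3 to compound 4 (0.69 log units; beyond the scatter). The same holds against the chain of compound 2, an at least 5.0-fold lower number from compound 2 to compound 4 (0.69 log units; beyond the scatter), while the benzamido group proves unnecessary for a readable number, with no change at the digits printed from compound 1 to compound 4 (within the scatter). Both lower steps are floors, resting on limits and not on numbers: the limit of > 10000 nM in this assay, at which 2 of the 4 values shown sit.

Going by these compounds, whether the terminal amine or the chain length carries the step stays open. A plain hexyl chain, a 6-hydroxyhexyl chain or a shorter 4-aminobutyl chain would separate the two.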